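The source may report more compounds than this note shows. Statements on the series, on what has been measured and on what is new or still open speak of the compounds shown alone.

Working notes on the series. Compound 1, `Oc1cccc(-c2cc(-c3cccc(F)c3)cc(-c3ccccc3O)n2)c1`, is known in a functional assay on HCT-15 cells (Homo sapiens) for inhibition (a higher number here means a weaker inhibitor, a lower number a stronger inhibitor), only as a limit: compound 1 gives > 50000 nM, which is a limit of the assay and not a number, as noted in the limit of > 50000 nM in this assay, at which 1 of the 2 values shown sits. Compound 2, `Oc1ccc(-c2cc(-c3cccc(F)c3)cc(-c3cccc(O)c3)n2)cc1`, in this assay gives 3070 nM. Within the data shown here, the one measured step, an at least 16-fold lower number from compound 1 to compound 2 (1.21 log units; beyond the scatter), concerns the 2-hydroxyphenyl group and not the group changed here.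

Compound 3, `Oc1cccc(-c2cc(-c3ccc(C(F)(F)F)cc3)cc(-c3ccccc3O)n2)c1`, differs from compound 1 by 4-(trifluoromethyl)phenyl in place of 3-fluorophenyl on an aromatic carbon. Among the measured compounds shown here, no measured step touches this position or this pair of groups, so the measured data give no direction for the change. With compound 1 sitting at a limit, the expectation is that the step that the limit leaves unreadable from compound 1 to compound 3 stays within the scatter, and that compound 3 is likely to be reported again as a limit. For compound 3 the estimated value in this assay is 80000 nM, with a range from 20000 nM to 300000 nM.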

Compound 3, half-maximal inhibitory concentration: > 50000 nM
Compound 3 ended at the assay's limit; the forecaster's own chance of this, stated with the estimate: 70%; the middle value is on the limit's open side.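

No step can be read from compound 1 to compound 3, as both stand at a limit and not a number in this assay: the limit of > 50000 nM in this assay, at which 2 of the 3 values shown sit. The compounds shown leave open how 4-(trifluoromethyl)phenyl and 3-fluorophenyl compare where the read-out gives a number.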